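Swapping cyclopropyl for thiophen-3-yl on the shared core

The compounds below may be only part of what the source reports. "The series", "measured", "known", "first", "only" and "open" are said of these compounds alone.

Values in an ADME assay on MDCK cells (Canis lupus familiaris) for cytotoxicity, read by MTT assay, with a stated time of 48 h; on this read-out lower numbers stand for higher toxicity in this test and higher numbers for lower toxicity in this test:
- compound 1 `CC(C)(C)c1ccc(-c2cn(CC3=C(Cl)c4ccc(-c5cccs5)nc4CC3)nn2)cc1`: 172 ug/mL
- compound 2 `Fc1ccc(-c2cn(CC3=C(Cl)c4ccc(-c5cccs5)nc4CC3)nn2)cc1`: 100 ug/mL
- compound 3 `ClC1=C(Cn2cc(C3CC3)nn2)CCc2nc(-c3cccs3)ccc21`: > 300 ug/mL, a limit of the assay

As far as these compounds go, compound 3 stands at > 300 ug/mL, which is a limit and not a number, so its exact place on the scale is unknown.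

Compound 4 `ClC1=C(Cn2cc(-c3ccsc3)nn2)CCc2nc(-c3cccs3)ccc21` carries thiophen-3-yl in place of cyclopropyl on an aromatic carbon. A five-membered aromatic ring thus takes the place of a three-membered non-aromatic ring.

Two measured steps change the same carbon, both going from an aromatic substituent to cyclopropyl: an at least 1.7-fold higher number from compound 1 to compound 3 (0.24 log units; that floor lies within the scatter) and an at least 3.0-fold higher number from compound 2 to compound 3 (0.47 log units; beyond the scatter). Only the second of these clears the scatter. The two aromatic substituents themselves do not separate, as a 1.7-fold lower number from compound 1 to compound 2 (0.24 log units; within the scatter) shows.

Since an aromatic ring returns at that carbon, a change opposite in direction to an at least 3.0-fold higher number from compound 2 to compound 3 (0.47 log units; beyond the scatter) and of similar size is expected in this assay, towards a lower number. For the measured compounds named here, only two compounds support this reading, and the limit on compound 3 leaves the true size open.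

The expected change is an at least 2.3-fold lower number from compound 3 to compound 4 (0.36 log units; beyond the scatter).

For compound 4 the estimate is 130 ug/mL, with an expected range of 60 ug/mL to 280 ug/mL.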

Compound 4, half-maximal cytotoxic concentration: > 300 ug/mL
Compound 4 ended at the assay's limit; the forecaster's own chance of this, stated with the estimate: 15%; middle value at least 2.3-fold (0.36 log units) away from the limit.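

On this aromatic carbon, an aromatic ring does not by itself bring the number down in this assay: thiophen-3-yl in place of 4-fluorophenyl gives an at least 3.0-fold higher number from compound 2 to compound 4 (0.47 log units; beyond the scatter), while thiophen-3-yl in place of 4-(tert-butyl)phenyl gives an at least 1.7-fold higher number from compound 1 to compound 4 (0.24 log units; that floor lies within the scatter). The separation from the aromatic substituents that earlier rested on cyclopropyl in compound 3 is therefore no longer tied to a non-aromatic ring, at least against the 4-fluorophenyl of compound 2, and compound 1 does not clearly support or oppose this reading. The step between compound 3 and compound 4 cannot be read, because both compounds sit at the limit of the assay: the limit of > 300 ug/mL in this assay, at which 2 of the 4 values shown sit.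

As far as these compounds go, how far compound 3 and compound 4 lie beyond that limit remains open, so the two cannot be placed in order. Also open, from the compounds shown here alone, is whether an amine, a carboxylic acid or a longer chain on this carbon would stay at the limit or give a readable number.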